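Swapping the aryl group on the ketone of a fused core

A few compounds are considered here, and "the series" means these few. Any claim that something is new, unique, unknown or untested is made for them only; others in the source may bear on it.

Measured so far:
- compound 1, `COc1cc(Br)cc(/C=C/C(=O)c2ccc(Br)cc2)c1O`: 48.3%
- compound 2, `COC(=O)C1=C(N)Oc2c(OC)cc(Br)cc2C1CC(=O)c1ccc(Cl)cc1`: 33.8%
- compound 3, `COC(=O)C1=C(N)Oc2c(OC)cc(Br)cc2C1CC(=O)c1cccc(OC)c1`: 94.9%

These three compounds were tested in a functional assay on MCF7 cells (Homo sapiens) for antiproliferative activity, read by sulforhodamine B assay, with a stated time of 72 h, tested at 30 uM; a higher number here means a weaker effect of the compound at the concentration tested, a lower number a stronger effect. Compound 3 stands highest of the three numbers, meaning the weakest effect; its nearest neighbour is compound 1, and the gap to compound 2 is the largest, both beyond the scatter.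

Compound 4, `COC(=O)C1=C(N)Oc2c(OC)cc(Br)cc2C1CC(=O)c1ccc(Br)cc1`, is not yet measured. It differs from compound 3 in one place: 4-bromophenyl in place of 3-methoxyphenyl on a carbonyl carbon. Going by the values given here, only one measured step bears on this change: a number 61.1 percentage points higher from compound 2 to compound 3 (beyond the scatter). That step exchanged a 4-chlorophenyl for a 3-methoxyphenyl on the same carbonyl carbon and raised the number strongly. The change to compound 4 runs the other way, putting a 4-bromophenyl, a halogen-bearing ring much like the 4-chlorophenyl of compound 2, in place of the 3-methoxyphenyl. A large fall, back toward compound 2, is therefore expected in this assay.

The expected step is a number 54.9 percentage points lower from compound 3 to compound 4 (beyond the scatter). Compound 4 is estimated at 40%, with a range from 22% to 65%.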

Compound 4, a percentage reported as activity, at one concentration (the size of the read-out at that concentration, not a potency): 31.9%
Compound 4: the middle estimate sits 8.1 percentage points above what was measured; the range from low to high includes it.
By their numbers in this assay, from the lowest: compounds 4 and 2 (each within the scatter of the next); then compound 1; then compound 3.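

In this assay, putting 4-bromophenyl in place of 3-methoxyphenyl on a carbonyl carbon gives a number 63 percentage points lower from compound 3 to compound 4 (beyond the scatter), so a second halogen-bearing ring now stands apart from the methoxy-bearing one on the shared core. Exchanging only the halogen, bromo in place of chloro on an aromatic carbon, gives a number 1.9 percentage points lower from compound 2 to compound 4 (within the scatter), so chloro and bromo cannot be told apart in this pair. No supporting information is available to explain the gap between these rings.

The compounds shown leave open whether the high number of compound 3 goes with the methoxy group itself or simply with the absence of a halogen. On these data alone, how a plain phenyl, or a ring carrying an amine or a carboxylic acid, would read on this carbonyl carbon also remains open.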